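Pyridine carboxamide series: methoxy for methyl, expected to stay inactive

The source may hold more compounds than are shown below. What is called first, only, known or untested is meant among the compounds shown, and "the series" means these compounds.

Compound 1, `Cc1ccc(-c2ccc(C(=O)Nc3ccc(Oc4ccnc5[nH]ccc45)cc3)nc2)cc1`: in a functional assay on PC-3 cells (Homo sapiens) for cytotoxicity, read by MTT assay, with a stated time of 72 h (a lower number here means a stronger inhibitor, a higher number a weaker inhibitor), compound 1 gives > 10000 nM, a limit of the assay.
Compound 2, `COc1ccc(-c2ccc(C(=O)Nc3ccc(Oc4ccnc5[nH]ccc45)cc3)nc2)cc1`: in this assay compound 2 gives > 10000 nM, a limit of the assay.
Compound 3, `Cc1ccc(-c2ccnc(C(=O)Nc3ccc(Oc4ccnc5[nH]ccc45)cc3)c2)cc1`: in this assay compound 3 gives > 10000 nM, a limit of the assay.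

Compound 3 stands at a limit, and no number for it is known. The same holds for the whole set, since (the limit of > 10000 nM in this assay, at which 3 of the 3 values shown sit). The change to compound 4, `COc1ccc(-c2ccnc(C(=O)Nc3ccc(Oc4ccnc5[nH]ccc45)cc3)c2)cc1`, is methoxy in place of methyl on an aromatic carbon. Among the measured compounds shown here, the one measured step of this kind, a step that the two limits leave unreadable from compound 1 to compound 2, cannot be read, as both of its ends are limits. Nothing shown therefore points to any readable step in this assay, in either direction. Compound 4 is expected to sit at the limit as well, with a step that the limit leaves unreadable from compound 3 to compound 4 that is only nominal. The estimate for compound 4 is 15000 nM, within 5000 nM to 50000 nM, and most likely the assay again reports only a limit.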

Compound 4, half-maximal inhibitory concentration: 9620 nM
Compound 4: the middle estimate sits 1.6-fold (0.19 log units) above what was measured, and the stated range covers the measured number.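

Among the compounds shown here, the change from 4-methylphenyl to 4-methoxyphenyl gives an at least 1.0-fold lower number from compound 3 to compound 4 (0.01 log units; that floor lies within the scatter), which makes compound 4 the first compound in the set with a number rather than a limit. Going by these compounds, only a floor is available for this step, so its true size stays unknown, and the same change in the other pair cannot be read, as both of its ends are limits. Readable numbers remain scarce: the limit of > 10000 nM in this assay, at which 3 of the 4 values shown sit.

Still open, on these data alone, is whether an amine, a carboxylic acid or a longer chain such as ethoxy at this position would move the number in this assay clearly beyond the scatter.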